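Ester to acid on a butenolide scaffold: an expected small step

The source may report more compounds than this note shows. Statements on the series, on what has been measured and on what is new or still open speak of the compounds shown alone.

The series was measured in an assay on isolated protein for inhibition of Alpha glucosidase (Homo sapiens), read by spectrophotometry, with stated times of 5 min and 15 min; on this read-out higher numbers stand for weaker inhibition and lower numbers for stronger inhibition. Compound 1 `COC(=O)[C@]1(Cc2ccc3c(c2)C[C@@H](O)C(C)(C)O3)OC(=O)C(O)=C1c1ccc(O)cc1` gives 110000 nM. Compound 2 `CO[C@@H]1OC(=O)C(Cc2ccc(O)c(CC=C(C)C)c2)=C1c1ccc(O)cc1` gives 9980 nM. Compound 3 `COC(=O)[C@@]1(O)OC(=O)C(Cc2ccc3c(c2)CCC(C)(C)O3)=C1c1ccc(O)cc1` gives 10300 nM, the second highest of the three numbers; its nearest neighbour is compound 2, whose number lies within the scatter of that of compound 3, while the number of compound 1 lies higher and beyond the scatter. Compound 4 `CC1(C)CCc2cc(CC3=C(c4ccc(O)cc4)[C@@](O)(C(=O)O)OC3=O)ccc2O1` differs from compound 3 by hydrogen in place of methyl on an oxygen next to a carbonyl group, in words: hydrogen in place of methyl on an oxygen next to a carbonyl group. No such change has been measured within this set, so a step of at most modest size, in either direction or none beyond the scatter, is expected here: a 1.2-fold higher number from compound 3 to compound 4 (0.07 log units; within the scatter). Compound 4 is estimated to give 12000 nM, within a range of 4000 nM to 40000 nM in this assay.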

Compound 4, half-maximal inhibitory concentration: 7630 nM
Estimate against measurement, compound 4: 1.6-fold (0.20 log units) above, within the range that was stated.
By their numbers in this assay, from the lowest: compounds 4, 2 and 3 (each within the scatter of the next); then compound 1.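

In this assay, hydrogen in place of methyl on an oxygen next to a carbonyl group gives a 1.3-fold lower number from compound 3 to compound 4 (0.13 log units; within the scatter). Among the compounds shown here, at this position, therefore, methoxycarbonyl and carboxy cannot be told apart on this read-out, which is the first reading of this change. Nothing measured here offers an explanation for this result. On these data alone, whether an amide or an ethyl ester would also leave the number within the scatter remains open. So does whether the same change would give a similar step on the core of compound 1.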